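Series notes: trifluoromethoxy analogue of compound 1

The source may hold more compounds than are shown below. What is called first, only, known or untested is meant among the compounds shown, and "the series" means these compounds.

Measured so far:
compound 1 `O=C(Cc1cccnc1)c1cc2ccccc2[nH]1`: 13%
compound 2 `O=C(Cc1cnccn1)c1cc2ccccc2[nH]1`: "not active" (no number reported)
compound 3 `COc1cccc2[nH]c(C(=O)Cc3cccnc3)cc12`: "not active" (no number reported)

Among the measured compounds shown here, in an in vitro assay on P815B cells for inhibition of Indoleamine 2,3-dioxygenase 1 (Mus musculus), tested at 20 uM (a lower number here means less inhibition, a higher number more inhibition at the concentration tested (going by the name of the read-out)), compound 1 gives 13%, the only number in the set; compound 2 is recorded as "not active" (no number reported) and compound 3 as "not active" (no number reported), so no step between measured compounds can be sized. Compound 3, which bears a methoxy on the shared core, adds nothing numerical. Compound 4 `O=C(Cc1cccnc1)c1cc2cc(OC(F)(F)F)ccc2[nH]1` differs from compound 1 by trifluoromethoxy in place of hydrogen on an aromatic carbon. For the measured compounds named here, nothing in the set shows that trifluoromethoxy in place of hydrogen shifts this assay beyond the scatter; if anything the bare core of compound 1 is the one entry with a number. Compound 4 is therefore expected to show 10%, within 0% to 25%, with a real chance of being reported only as not active. The expected step of a number 3 percentage points lower from compound 1 to compound 4 (within the scatter) stays inside the scatter.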

Compound 4, a percentage reported as inhibition, at one concentration (the size of the read-out at that concentration, not a potency): 12%
Compound 4: the middle estimate sits 2 percentage points below what was measured; the measured number falls inside the stated range.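

Trifluoromethoxy in place of hydrogen on this aromatic carbon gives, in this assay, a number 1 percentage points lower from compound 1 to compound 4 (within the scatter), the first step in the series that can be read. This position therefore accepts a group of 5 heavy atoms while the reading stays within the scatter of the bare core. No supporting data bear on this result.

The steps involving the entries without a number cannot be read. Going by these compounds, whether an amine or a carboxylic acid on this same carbon would move the reading beyond the scatter remains open.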